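The source may report more compounds than this note shows. Statements on the series, on what has been measured and on what is new or still open speak of the compounds shown alone.

Measured so far in a functional assay on MCF7 cells (Homo sapiens) for antiproliferative activity, read by sulforhodamine B assay, with a stated time of 72 h (on this read-out higher numbers stand for weaker inhibition and lower numbers for stronger inhibition), are three compounds. Compound 1, `FC(F)(F)c1ccc(CN2CCN(Cc3cc(-c4ccc(OCc5ccccc5Cl)cc4)on3)CC2)cc1`, gives 2800 nM. Compound 2, `Fc1ccccc1COc1ccc(-c2cc(CN3CCN(Cc4ccc(C(F)(F)F)cc4)CC3)no2)cc1`, gives 3000 nM. Compound 3, `Fc1cccc(COc2ccc(-c3cc(CN4CCN(Cc5ccc(C(F)(F)F)cc5)CC4)no3)cc2)c1`, gives 2500 nM.

Compound 3 holds the lowest of the three numbers, yet its gaps to compound 1 and compound 2 are both within the scatter, so the three compounds cannot be told apart on these data. The measured steps bear this out: a 1.1-fold higher number from compound 1 to compound 2 (0.03 log units; within the scatter), a 1.1-fold lower number from compound 1 to compound 3 (0.05 log units; within the scatter) and a 1.2-fold lower number from compound 2 to compound 3 (0.08 log units; within the scatter), each of them within the scatter.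

Compound 4, `COc1cc(COc2ccc(-c3cc(CN4CCN(Cc5ccc(C(F)(F)F)cc5)CC4)no3)cc2)cc(OC)c1OC`, differs from compound 3 in one place: 3,4,5-trimethoxyphenyl in place of 3-fluorophenyl on a saturated chain carbon bound to an oxygen on an aromatic ring. Going by the values given here, the measured steps all concern a halogen on the phenyl bound to the oxygen and say only that such changes left this assay unmoved. None of them involves a 3,4,5-trimethoxyphenyl, so they give no direct guide to the size or direction of this step. The expectation therefore rests on compound 3 and its value 2500 nM, with a wide range to either side. For compound 4 the estimated step is a 1.3-fold lower number from compound 3 to compound 4 (0.10 log units; within the scatter). Compound 4 is expected to give about 2000 nM, within a range from 600 nM to 7000 nM.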

Compound 4, half-maximal inhibitory concentration: 1800 nM
Beside the measured number, compound 4's estimate is 1.1-fold (0.05 log units) above it; measured number inside the range.
By their numbers in this assay, from the lowest: compounds 4, 3, 1 and 2 (each within the scatter of the next).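

Exchanging the 3-fluorophenyl for 3,4,5-trimethoxyphenyl, on a saturated chain carbon bound to an oxygen on an aromatic ring, replaces a group of 7 heavy atoms and 0 hydrogen-bond acceptors with one of 12 heavy atoms and 3 hydrogen-bond acceptors. Even so, this assay shows a 1.4-fold lower number from compound 3 to compound 4 (0.14 log units; within the scatter), and the comparisons with the two ortho-free wording aside are equally small: a 1.7-fold lower number from compound 2 to compound 4 (0.22 log units; within the scatter) and a 1.6-fold lower number from compound 1 to compound 4 (0.19 log units; within the scatter). Going by these compounds alone, the earlier compounds showed only that halogen changes on this phenyl left the number unmoved, whereas compound 4 extends this to a much larger group carrying oxygen atoms, with no step here beyond the scatter. Nothing available explains why the number holds across this change.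

From the compounds shown here alone, whether this position would respond to a phenyl carrying an amine or a carboxylic acid, or to a longer chain in place of the phenyl, remains open. Going by these compounds, the trifluoromethyl group is also common to all four compounds, so the effect of a nitrile in its place on this read-out is unknown.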